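The source may hold more compounds than are shown below. What is called first, only, known or untested is meant among the compounds shown, and "the series" means these compounds.

Measured so far in a functional assay on SiHa cells (Homo sapiens) for cytotoxicity, with a stated time of 4 h; a lower number here means a stronger inhibitor, a higher number a weaker inhibitor:

Compound 1 `CN(C)CCNc1n[n+]([O-])c2ccccc2[n+]1[O-]`: 200 nM
Compound 2 `[O-][n+]1nc(NCCN2CCCCC2)[n+]([O-])c2ccccc21`: 1100 nM
Compound 3 `CCOc1ccc2c(c1)[n+]([O-])c(NCCN(C)C)n[n+]2[O-]`: 800 nM

Compound 1 and compound 2 share one core and differ in a single place, (piperidin-1-yl in place of dimethylamino on a saturated chain carbon, two bonds along the chain from a nitrogen on an aromatic ring). That change gave a 5.5-fold higher number from compound 1 to compound 2 (0.74 log units; beyond the scatter). Compound 3 carries a second core, which differs from the core of compound 1 by ethoxy in place of hydrogen on an aromatic carbon; this gave a 4.0-fold higher number from compound 1 to compound 3 (0.60 log units; beyond the scatter). Compound 3 and compound 2 are within the scatter of each other, so no order can be read between them.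

Compound 4 `CCOc1ccc2c(c1)[n+]([O-])c(NCCN1CCCCC1)n[n+]2[O-]` has not been measured in this assay. It stands to compound 3 as compound 2 stands to compound 1: the difference is piperidin-1-yl in place of dimethylamino on a saturated chain carbon, two bonds along the chain from a nitrogen on an aromatic ring, at the same place as before, so it is the same change on the second core. Among the measured compounds shown here, compound 4 is expected to show a step of a 5.0-fold higher number from compound 3 to compound 4 (0.70 log units; beyond the scatter), which rests on the single earlier pairing because a 5.5-fold higher number from compound 1 to compound 2 (0.74 log units; beyond the scatter) is the only measured instance of this change. On that basis compound 4 is estimated at 4000 nM, within a range from 1500 nM to 10000 nM.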

Compound 4, half-maximal inhibitory concentration: 1700 nM
Compound 4: the middle estimate sits 2.4-fold (0.37 log units) above what was measured; low and high end bracket the measured number.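

In this assay, piperidin-1-yl in place of dimethylamino on the second core, the one carrying ethoxy, gave a 2.1-fold higher number from compound 3 to compound 4 (0.33 log units; beyond the scatter), a step in the same direction as on the first core and no different from the earlier step once the scatter is allowed for: the same change on two cores in this assay, a 5.5-fold higher number (0.74 log units; beyond the scatter) from compound 1 to compound 2 and a 2.1-fold higher number (0.33 log units; beyond the scatter) from compound 3 to compound 4, 2.6-fold (0.41 log units) apart, within the scatter of two such steps. Ethoxy in place of hydrogen, now read on the piperidine side, gave a 1.5-fold higher number from compound 2 to compound 4 (0.19 log units; within the scatter), a step within the scatter where the earlier one lay beyond it, yet these two steps also cannot be told apart: the same change on two cores in this assay, a 4.0-fold higher number (0.60 log units; beyond the scatter) from compound 1 to compound 3 and a 1.5-fold higher number (0.19 log units; within the scatter) from compound 2 to compound 4, 2.6-fold (0.41 log units) apart, within the scatter of two such steps. So the four compounds are consistent with each change carrying from one core to the other, but with a single pairing for each they fix no step size and do not show that either change would carry to any further core.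

The compounds shown leave open how another cyclic amine on the chain, such as morpholine or pyrrolidine, would compare with piperidin-1-yl. They also leave open what a longer chain, or methoxy in place of ethoxy, would do.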